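A few compounds are considered here, and "the series" means these few. Any claim that something is new, unique, unknown or untested is made for them only; others in the source may bear on it.

Compound 2, `Cc1ccccc1OCC1=NCCO1`, in a toxicity assay on the whole organism with Rattus norvegicus as the target, at a dose of 400 mg/kg by the oral route (on this read-out lower numbers stand for a weaker effect and higher numbers for a stronger effect at the one dose given), gives 40%. It stands level with compound 1, `Brc1ccccc1OCC1=NCCO1`, which in this assay gives 40%; no change at the digits printed from compound 1 to compound 2 (within the scatter). Compound 3, `Clc1ccccc1OCC1=NCCO1`, in this assay gives 80%; a number 40 percentage points higher from compound 2 to compound 3 (beyond the scatter) and a number 40 percentage points higher from compound 1 to compound 3 (beyond the scatter). Compounds 1 and 2 thus share the lowest of the three numbers, with compound 3 clearly higher than both.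

Compound 4, `Cc1ccc(OCC2=NCCO2)c(C)c1`, differs from compound 2 by methyl in place of hydrogen on an aromatic carbon. For the measured compounds named here, none of the measured steps bears directly on this change: each exchanges one group for another on the same aromatic carbon, and none puts a methyl where a hydrogen stood. The methyl already present in compound 2 is kept in compound 4. A swap of methyl for bromo was within the scatter, whereas the swap to chloro gave a large step; neither tells how an added methyl on a further aromatic carbon will behave. Going by the values given here, with no precedent, the expectation in this assay is a step of no size beyond the scatter, no change at the digits printed from compound 2 to compound 4 (within the scatter). Compound 4 is therefore estimated at about 40%, within a range from 15% to 70%.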

Compound 4, a percentage reported as activity, at one dose (the size of the read-out at that dose, not a potency): 18%
Compound 4: the middle estimate sits 22 percentage points above what was measured; low and high end bracket the measured number.
By their numbers in this assay, from the lowest: compound 4; then compounds 1 and 2 (each within the scatter of the next); then compound 3.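

In this assay, methyl in place of hydrogen on this aromatic carbon, meta to a methyl group and para to a group of 7 heavy atoms, gives a number 22 percentage points lower from compound 2 to compound 4 (beyond the scatter), so this position is not silent to substitution. This is the only step shown that adds a group to a carbon bearing hydrogen, whereas the earlier steps exchanged one group for another on a single aromatic carbon. Its direction is downward, opposite to a number 40 percentage points higher from compound 2 to compound 3 (beyond the scatter), and no measurement shown accounts for the drop.

As far as these compounds go, whether an amine or a methoxy group on this carbon would also lower the number remains open. Also open, from the compounds shown here alone, is whether the added methyl gives a step of similar size and direction when chloro, as in compound 3, replaces the existing methyl.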